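Neopentyl ketone series: trimming the ketone chain in compound 4

The compounds below may be only part of what the source reports. "The series", "measured", "known", "first", "only" and "open" are said of these compounds alone.

Measured in an assay on HEK293 cells for positive allosteric modulation of metabotropic glutamate receptor 3 (Rattus norvegicus), read by thallium flux, with a stated time of 2.5 min; a lower number here means that less compound is needed, a higher number that more compound is needed for the effect:
compound 1 `Cc1c(OCCCCOc2ccc(C(=O)CC(C)(C)C)c(O)c2C)cccc1C(=O)O`: 300 nM
compound 2 `Cc1c(OCCCCOc2ccc(F)c(C(=O)O)c2)ccc(C(=O)CC(C)(C)C)c1O`: 258 nM
compound 3 `Cc1cc(C(=O)O)ccc1OCCCCOc1ccc(C(=O)CC(C)C)c(O)c1C`: 1850 nM

Compound 1 stands second highest of the three numbers; compound 2 lies within the scatter of it, a 1.2-fold lower number from compound 1 to compound 2 (0.07 log units; within the scatter), while compound 3 gives a clearly higher number. Compound 4 `CCCC(=O)c1ccc(OCCCCOc2cccc(C(=O)O)c2C)c(C)c1O` differs from compound 1 in one place: ethyl in place of tert-butyl on a saturated chain carbon bound to a carbonyl carbon. For the measured compounds named here, no measured step changes this chain alone; the single step between compound 1 and compound 2 concerns the aryl on the ether and says nothing about it. Compound 3 carries a different chain but also another aryl, so its higher number cannot be assigned. Going by the values given here, with no direct precedent, a moderate rise in this assay is expected for compound 4, a 2.7-fold higher number from compound 1 to compound 4 (0.43 log units; beyond the scatter), giving an estimate of 800 nM with a range of 250 nM to 2500 nM.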

Compound 4, half-maximal effective concentration: > 10000 nM
Compound 4 gave a limit, no number; the forecaster's own chance of this, stated with the estimate: 5%; middle value at least 12-fold (1.09 log units) from the limit.
By their numbers in this assay, from the lowest: compounds 2 and 1 (each within the scatter of the next); then compound 3. At a limit, above all of these: compound 4.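

In this assay, the change from neopentylcarbonyl to propylcarbonyl, with all else unchanged, gives an at least 33-fold higher number from compound 1 to compound 4 (1.52 log units; beyond the scatter). For the compounds shown here, this is the first read on the ketone chain, and trimming it alone takes the core of compound 1 out of the measurable range. Compound 4 gives a limit, not a number: the limit of > 10000 nM in this assay, at which 1 of the 4 values shown sits.

The chain of compound 3 comes with a different aryl, so it cannot show how the number changes along the chain. As far as these compounds go, how a longer unbranched chain such as pentyl, or a cyclopropyl or cyclohexyl in place of tert-butyl, would read on this core remains open.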